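The source may hold more compounds than are shown below. What is called first, only, known or untested is meant among the compounds shown, and "the series" means these compounds.

The measured compounds and their values:

Compound 1, `O=c1c(CSC(=S)N2CCOCC2)coc2cc(Cl)ccc12`, gives 2000 nM in a functional assay on HeLa cells (Homo sapiens) for antiproliferative activity, read by MTT assay, with a stated time of 72 h; on this read-out lower numbers stand for stronger inhibition and higher numbers for weaker inhibition.
Compound 2, `O=c1c(CSC(=S)N2CCCCC2)coc2cc(Cl)ccc12`, gives 440 nM in this assay.
Compound 3, `CCOC(=O)c1cc(=O)c2cc(CSC(=S)N3CCCCC3)ccc2o1`, gives 5800 nM in this assay.

Compound 4, `CCOC(=O)c1cc(=O)c2cc(CSC(=S)N3CCOCC3)ccc2o1`, has not yet been measured in this assay.

Compounds 1 and 2 share one core, and compounds 3 and 4 share another; the difference between the two cores is not broken down here. What the two values of compound 2 and compound 3 show is that compound 3 gives the higher number of the two. Among the three measured compounds, compound 3 stands highest, with compound 1 nearest to it and compound 2 furthest from it.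

Within the first core, the change from compound 2 to compound 1 is morpholin-4-yl in place of piperidin-1-yl on a thiocarbonyl carbon. That step gave a 4.5-fold higher number from compound 2 to compound 1 (0.66 log units; beyond the scatter). The change from compound 3 to compound 4 is morpholin-4-yl in place of piperidin-1-yl on a thiocarbonyl carbon, and since the place where the change is made is the same word for word, it is the same change, now made on the second core.

Because compound 3 already gives 5800 nM, and because the same change from compound 2 to compound 1 gave a 4.5-fold higher number from compound 2 to compound 1 (0.66 log units; beyond the scatter), compound 4 is expected to show a step of about a 3.8-fold higher number from compound 3 to compound 4 (0.58 log units; beyond the scatter). The estimate for compound 4 is 22000 nM, expected to fall between 7000 nM and 70000 nM.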

Compound 4, half-maximal inhibitory concentration: > 25000 nM
Compound 4 gave a limit, no number; the forecaster's own chance of this, stated with the estimate: 15%; middle value at least 1.1-fold (0.05 log units) from the limit.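

In this assay, compound 4 gives > 25000 nM, which is a limit of the assay and not a number. Putting morpholin-4-yl in place of piperidin-1-yl on the thiocarbonyl carbon gave an at least 4.3-fold higher number from compound 3 to compound 4 (0.63 log units; beyond the scatter), so the number rose on the second core, as it had on the first. This shows that the direction of the change carried over in these two pairs, but it does not show that the size carried over, since the true value of compound 4 remains unknown: the same change on two cores in this assay, a 4.5-fold higher number (0.66 log units; beyond the scatter) from compound 2 to compound 1 and an at least 4.3-fold higher number (0.63 log units; beyond the scatter) from compound 3 to compound 4; the limit leaves it open whether they differ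

The compounds shown carry only piperidin-1-yl and morpholin-4-yl on the thiocarbonyl carbon, so it remains open whether other amines, such as pyrrolidin-1-yl, piperazin-1-yl or an open-chain diethylamino group, would follow the same course on either core. Also open, going by these compounds, is whether the same step would appear on a core carrying a carboxylic acid in place of the ethyl ester found in compound 3 and compound 4.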